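Nitrile series: a (2-methylbenzyl)oxy arm on compound 1

The compounds below may be only part of what the source reports. "The series", "measured", "known", "first", "only" and "open" are said of these compounds alone.

Measured in an assay for inhibition of cathepsin S (Homo sapiens) (on this read-out lower numbers stand for stronger inhibition and higher numbers for weaker inhibition), so far:
compound 1, `CC(C)C[C@H](NC(=O)N1CCOCC1)C(=O)N[C@@H](C)C#N`: 142 nM
compound 2, `CC(C)C[C@H](NC(=O)N1CCOCC1)C(=O)NC(C)(C)C#N`: 114 nM

Compound 1 has the highest of the two numbers; the nearest is compound 2, reached by a 1.2-fold lower number from compound 1 to compound 2 (0.10 log units; within the scatter), a step within the scatter, so the two compounds cannot be ordered against each other.

Compound 3, `Cc1ccccc1COC[C@@H](C#N)NC(=O)[C@H](CC(C)C)NC(=O)N1CCOCC1`, has not been measured. It differs from compound 1 by (2-methylbenzyl)oxy in place of hydrogen on a saturated chain carbon, two bonds along the chain from an amide-type nitrogen and a triple-bonded carbon. Among the measured compounds shown here, no measured step covers this change. For the measured compounds named here, the only step in hand, a 1.2-fold lower number from compound 1 to compound 2 (0.10 log units; within the scatter), touches the same chain carbon but adds only a methyl and stayed within the scatter; it shows that the position tolerates a small addition without telling how a larger one behaves. The direction of the step in this assay is therefore open. Compound 3 is nonetheless expected to give a step of a 3.6-fold lower number from compound 1 to compound 3 (0.55 log units; beyond the scatter) toward a lower number, a working guess held with a wide range. For compound 3 the estimate in this assay is 40 nM, between 8 nM and 200 nM.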

Compound 3, half-maximal inhibitory concentration: 19 nM
Beside the measured number, compound 3's estimate is 2.1-fold (0.32 log units) above it; measured number inside the range.
By their numbers in this assay, from the lowest: compound 3; then compounds 2 and 1 (each within the scatter of the next).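

In this assay the saturated chain carbon, two bonds along the chain from an amide-type nitrogen and a triple-bonded carbon, now shows a step beyond the scatter: (2-methylbenzyl)oxy in place of hydrogen gives a 7.5-fold lower number from compound 1 to compound 3 (0.87 log units; beyond the scatter), whereas the earlier step, a 1.2-fold lower number from compound 1 to compound 2 (0.10 log units; within the scatter), showed only that a methyl left the number within the scatter. The position therefore accepts much more than a small addition, here an arm of 9 heavy atoms with one six-membered aromatic ring of carbon only and 1 hydrogen-bond acceptor, and the number falls rather than rises. No supporting evidence bears on why the number falls.

With a single arm shown, it remains open whether the step rests on the aromatic ring, on its methyl or on the ether oxygen, a question that an unsubstituted benzyloxy, a plain methoxy or a benzylamino arm would help to separate. Also open, from the compounds shown here alone, is how this assay responds to an amine or a carboxylic acid placed on such an arm.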